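Aryl variation on the triaryl acrylic acid series

The source may report more compounds than this note shows. Statements on the series, on what has been measured and on what is new or still open speak of the compounds shown alone.

Measured so far:
compound 1 `CC/C(=C(/c1ccc(/C=C/C(=O)O)cc1)c1cc2ccccc2[nH]1)c1ccccc1C`, 33 nM
compound 2 `CC/C(=C(/c1ccc(/C=C/C(=O)O)cc1)c1cc2ccccc2[nH]1)c1ccc(C#N)cc1Cl`, 49 nM

Compound 2 holds the higher of the two numbers in a functional assay on MCF7 cells (Homo sapiens) for inhibition (a lower number here means a stronger inhibitor, a higher number a weaker inhibitor), with compound 1 nearest; the step of a 1.5-fold higher number from compound 1 to compound 2 (0.17 log units; within the scatter) lies within the scatter. Compound 3 `CC/C(=C(/c1ccc(/C=C/C(=O)O)cc1)c1cc2ccccc2[nH]1)c1cc(Cl)ccc1Cl` differs from compound 2 by 2,5-dichlorophenyl in place of 2-chloro-4-cyanophenyl on a double-bonded chain carbon bound to a double-bonded chain carbon and a saturated chain carbon. For the measured compounds named here, only that one step bears on the change; it was within the scatter, so no step beyond the scatter is expected in this assay in either direction. Compound 3 is therefore estimated at 45 nM (range 18 nM to 110 nM), an expected step of a 1.1-fold lower number from compound 2 to compound 3 (0.04 log units; within the scatter).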

Compound 3, half-maximal inhibitory concentration: 71 nM
Compound 3: middle estimate off by 1.6-fold (0.20 log units), on the low side, and the stated range covers the measured number.
By their numbers in this assay, from the lowest: compounds 1, 2 and 3 (each within the scatter of the next, the first and the last beyond it).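

In this assay, 2,5-dichlorophenyl in place of 2-chloro-4-cyanophenyl gives a 1.4-fold higher number from compound 2 to compound 3 (0.16 log units; within the scatter) and so does not separate the two compounds. Set against 2-methylphenyl, the same group gives a 2.2-fold higher number from compound 1 to compound 3 (0.33 log units; beyond the scatter) and this is the only step among the three compounds beyond the scatter, showing a modest response to the aryl group at this position. Nothing available explains that step. Still open, going by these compounds, is how a phenyl ring carrying an amine or a methoxy group would compare here with compound 1 and compound 3.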